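Methyl on the quinazoline core: a small step repeated

A few compounds are considered here, and "the series" means these few. Any claim that something is new, unique, unknown or untested is made for them only; others in the source may bear on it.

Measured compounds:
Compound 1, `Clc1ccccc1COc1ccccc1/C=C/C(/C=C/c1ccccn1)=N/Oc1ncnc2ccccc12`, in a functional assay on SMMC-7721 cells (Homo sapiens) for inhibition, read by MTT assay, with a stated time of 72 h, tested at 10 uM (a higher number here means a stronger effect of the compound at the concentration tested, a lower number a weaker effect), compound 1 gives 96%.
Compound 2, `Cc1cccc(COc2ccc(/C=C/C(/C=C/c3ccccn3)=N/Oc3ncnc4cccc(C)c34)cc2)c1`, in this assay compound 2 gives 97%.
Compound 3, `Cc1cccc(COc2ccc(/C=C/C(/C=C/c3ccccn3)=N/Oc3ncnc4ccccc34)cc2)c1`, in this assay compound 3 gives 97.5%.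

All three measured compounds sit close together, and the difference between the core of compound 1 and the core of compound 3 is not broken down here. Compound 3 and compound 2 differ in one place:

methyl in place of hydrogen on an aromatic carbon

This change produced a number 0.5 percentage points lower from compound 3 to compound 2 (within the scatter), so the two compounds give numbers that cannot be told apart in this assay.

The unmeasured compound 4, `Cc1cccc2ncnc(O/N=C(\C=C\c3ccccn3)/C=C/c3ccccc3OCc3ccccc3Cl)c12`, arises from compound 1 by the same change, made on the core shared with compound 3 and compound 2:

methyl in place of hydrogen on an aromatic carbon

Because the same change gave a number 0.5 percentage points lower from compound 3 to compound 2 (within the scatter), and because compound 1 already gives 96%, compound 4 is expected to stay at about the same level, with a step of no change at the digits printed from compound 1 to compound 4 (within the scatter). This rests on a single precedent, the pair of compound 3 and compound 2, and on nothing else. Compound 4 is therefore estimated to give 96% in this assay, expected to lie between 90% and 99%.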

Compound 4, a percentage reported as inhibition, at one concentration (the size of the read-out at that concentration, not a potency): 95.7%
Estimate against measurement, compound 4: 0.3 percentage points above, within the range that was stated.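

On the core of compound 1, the exchange of quinazolin-4-yl for 5-methylquinazolin-4-yl gave a number 0.3 percentage points lower from compound 1 to compound 4 (within the scatter), so in this assay the methyl left no readable mark there either. Set beside the earlier pair, the two steps agree, and the change carried from one core to the other without a difference that can be told from scatter: the same change on two cores in this assay, a number 0.5 percentage points lower (within the scatter) from compound 3 to compound 2 and a number 0.3 percentage points lower (within the scatter) from compound 1 to compound 4, 0.2 percentage points apart, within the scatter of two such steps This shows only that two pairs behaved alike in the size of the effect at one concentration; all four compounds give high numbers, so any stronger or weaker effect that a lower concentration might reveal would not be visible here, and two pairs do not establish a rule for the whole series.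

What the compounds shown leave open is whether a group other than methyl on this aromatic carbon, such as a longer chain, an amine or a carboxylic acid, would also leave the number in this assay where it stands. From the compounds shown here alone, it also remains open whether the methyl would give the same result on another carbon of this six-membered aromatic ring.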